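The compounds below may be only part of what the source reports. "The series", "measured", "known", "first", "only" and "open" are said of these compounds alone.

The shared core carries a methylidene cyclopropane bearing two hydroxymethyl groups; compound 1 is `Nc1nc2c(ncn2/C=C2/CC2(CO)CO)c(=O)[nH]1`, compound 2 is `Nc1nc(NC2CCCC2)c2ncn(/C=C3/CC3(CO)CO)c2n1`, compound 3 is `CCCCCCOc1nc(N)nc2c1ncn2/C=C1/CC1(CO)CO`, and the unmeasured compound 4 is `Nc1nc(SCc2ccccc2)c2ncn(/C=C3/CC3(CO)CO)c2n1`. Among the measured compounds shown here, the three measured members were run in an ADME assay on CCRF-HSB-2 cells (Homo sapiens) for cytotoxicity, with a stated time of 7 days; a higher number here means that more compound is tolerated, a lower number that less compound is tolerated. Compound 1 reaches only the limit of this assay, > 20000 nM. Compound 2 likewise stops at the limit, > 20000 nM. Compound 3 also sits at the limit, > 20000 nM. Compound 2 therefore stands where every other measured member stands: at a limit, not at a number, and it cannot be ordered against compound 1 or compound 3. For the measured compounds named here, the single measured one-point change, hexyloxy in place of cyclopentylamino on an aromatic carbon, yields a step that the two limits leave unreadable from compound 2 to compound 3, because of the limit of > 20000 nM in this assay, at which 3 of the 3 values shown sit.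

The next change is benzylsulfanyl in place of cyclopentylamino on an aromatic carbon. Going by the values given here, no measured step bears a readable size on it; the only comparable exchange at that aromatic carbon is the unreadable one from compound 2 to compound 3, and no effect of the entering benzylsulfanyl can be taken from the data. The expectation for compound 4 is that this assay again reports a limit, which as a step amounts to a step that the limit leaves unreadable from compound 2 to compound 4. Compound 4 is therefore estimated at 30000 nM, within 12000 nM to 100000 nM.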

Compound 4, half-maximal cytotoxic concentration: > 100000 nM
Compound 4 gave a limit, no number; the forecaster's own chance of this, stated with the estimate: 80%; middle value at least 3.3-fold (0.52 log units) away from the limit.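

In this assay compound 4 gives > 100000 nM, which is a limit and not a number. The steps from compound 2 and from compound 3 to compound 4 therefore cannot be read. The compounds shown leave open whether cyclopentylamino, hexyloxy and benzylsulfanyl on this aromatic carbon differ at all in the concentration tolerated.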